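Amino at the shared core: compound 3 to compound 4

The source may hold more compounds than are shown below. What is called first, only, known or untested is meant among the compounds shown, and "the series" means these compounds.

For the measured compounds named here, the three measured members share one core and differ in where the chloromethyl sits on the benzyl ring. In a functional assay on NCI-H460 cells (Homo sapiens) for cytotoxicity, read by sulforhodamine B assay, with a stated time of 48 h (a lower number here means that less compound is tolerated, a higher number that more compound is tolerated), compound 1 `ClCc1ccc(Cn2cnc3c(Cl)ncnc32)cc1` gives 26900 nM. Compound 2 `ClCc1ccccc1Cn1cnc2c(Cl)ncnc21` reaches only the assay limit, > 100000 nM. Compound 3 `ClCc1cccc(Cn2cnc3c(Cl)ncnc32)c1` likewise gives no number in this assay but a limit, > 100000 nM, so its standing among the three is open; it sits at the limit of > 100000 nM in this assay, at which 2 of the 3 values shown sit, as does compound 2. No step between measured compounds is shown.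

Compound 4 `Nc1nc(Cl)c2ncn(Cc3cccc(CCl)c3)c2n1` is compound 3 with amino in place of hydrogen on an aromatic carbon, the amino entering on an aromatic carbon of a six-membered aromatic ring with 2 nitrogen, between two ring nitrogen atoms, meta to a chloro group. Since compound 3 is known only as a limit, the direction of the step cannot be read from the data. Compound 4 is expected to stay near the limit, its estimated step being a number no higher from compound 3 to compound 4 (the limit leaves the size open). The estimate for compound 4 in this assay is 100000 nM, with a range from 20000 nM to 300000 nM.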

Compound 4, concentration lethal to 50% of the cells: 47900 nM
Compound 4: middle estimate off by 2.1-fold (0.32 log units), on the high side; measured number inside the range.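

In this assay, amino in place of hydrogen on the aromatic carbon between two ring nitrogen atoms gives an at least 2.0-fold lower number from compound 3 to compound 4 (0.31 log units; beyond the scatter). For the compounds shown here, this is the first readable change at this carbon, which carries hydrogen in compound 1, compound 2 and compound 3, whose differences lie only in the placement of the chloromethyl on the benzyl ring. The step is beyond the scatter, but its full size stays open, as compound 3 is known only as a limit: the limit of > 100000 nM in this assay, at which 2 of the 4 values shown sit.

Going by these compounds, whether amino gives a similar step with the chloromethyl placed as in compound 1 or compound 2 remains open. Also open, on these data alone, is whether a methylamino group, a hydroxyl or a longer chain on this carbon would behave as amino does.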